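This account rests on a few compounds, and the source may have more. Where it says the series, first, only, none or still open, it means among the compounds named here.

Working notes on the retinoid ester series

Compound 1 `COc1cc(O)c(C(=O)OC/C=C(C)/C=C/C=C(C)/C=C/C2=CCCCC2(C)C)c(O)c1` carries the shared core with a methoxy group on the aromatic ring. In a toxicity assay on cells (Fibroblast, Homo sapiens) for cytotoxicity (on this read-out lower numbers stand for stronger inhibition and higher numbers for weaker inhibition), compound 1 gives 14000 nM. For the measured compounds named here, this is the only plain number in hand for the series. Compound 2 `COc1cc(NC(C)=O)cc(C(=O)OC/C=C(C)/C=C/C=C(C)/C=C/C2=CCCCC2(C)C)c1O` is the other member measured so far. In this assay compound 2 gives < 10000 nM, which is a limit of the assay and not a number. Going by the values given here, the state of the data is summed up by the limit of < 10000 nM in this assay, at which 1 of the 2 values shown sits; no step between two measured compounds can be worked out from it.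

Compound 3 `CC(/C=C/C1=CCCCC1(C)C)=C\C=C\C(C)=C\COC(=O)c1c(O)cccc1O` is not yet measured. From compound 1 it differs by one change, (hydrogen in place of methoxy on an aromatic carbon). Among the compounds with values here, no measured step stands behind this change, so the expected step in this assay is none beyond the scatter, in no clear direction. The step from compound 1 to compound 3 is therefore expected to be no change at the digits printed from compound 1 to compound 3 (within the scatter). For compound 3 the estimate in this assay is 14000 nM, with a range from 5000 nM to 40000 nM.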

Compound 3, half-maximal inhibitory concentration: 14000 nM
Beside the measured number, compound 3's estimate shows no gap at the digits printed; measured number inside the range.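

Hydrogen in place of methoxy on an aromatic carbon, meta to two hydroxy groups and para to a large group, gives the first step of the series that can be read in this assay: no change at the digits printed from compound 1 to compound 3 (within the scatter). The methoxy group is therefore not required at this position for the value seen in this assay, and the shared core with hydrogen there stays in the same range of cytotoxicity as compound 1. The data shown give no reason for this outcome.

Compound 2 remains at < 10000 nM, which is a limit of the assay and not a number, so it adds no readable step. From the compounds shown here alone, whether this position tolerates other groups also remains open: a single pair covers only methoxy and hydrogen, and an amine, a carboxylic acid or a longer alkoxy chain on the same aromatic carbon could still shift the value in this assay.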